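The source may hold more compounds than are shown below. What is called first, only, known or untested is meant among the compounds shown, and "the series" means these compounds.

Compound 1, `CC(C)(C)c1ccc(-c2cc(-c3cn([C@H]4C[C@H](O)[C@@H](CO)O4)c(=O)[nH]c3=O)on2)cc1`, was tested in a functional assay on ACHN cells (Homo sapiens) for cytotoxicity, read by sulforhodamine B assay, tested at 10 uM (a higher number here means more inhibition at the concentration tested (going by the name of the read-out), a lower number less inhibition), where compound 1 gives 94.2%. Compound 2, `CC(=O)OC[C@H]1O[C@@H](n2cc(-c3cc(C)no3)c(=O)[nH]c2=O)C[C@@H]1OC(C)=O`, in this assay gives 96.4%. The two numbers lie within the usual scatter of each other, so compound 1 cannot be told apart from compound 2 on these data. Compound 3, `CCCCCCCCc1cc(-c2cn([C@H]3C[C@H](O)[C@@H](CO)O3)c(=O)[nH]c2=O)on1`, has not yet been measured. It differs from compound 1 in one place: octyl in place of 4-(tert-butyl)phenyl on an aromatic carbon. Among the compounds with values here, no pair of measured compounds shows the effect of such a change, and compound 2 carries a different group at that carbon, so no measured step can be leaned on. Compound 1 gives 94.2% and compound 2 gives 96.4%, both high numbers in this assay, which leaves little room for a rise. The step of a number 6.2 percentage points lower from compound 1 to compound 3 (within the scatter) is therefore expected to be small, most likely within the scatter, with any deviation more plausibly downward than upward. Compound 3 is estimated at 88%, with a likely range from 60% to 100%.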

Compound 3, a percentage reported as inhibition, at one concentration (the size of the read-out at that concentration, not a potency): 95.6%
Beside the measured number, compound 3's estimate is 7.6 percentage points below it, within the range that was stated.
By their numbers in this assay, from the lowest: compounds 1, 3 and 2 (each within the scatter of the next).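

Within the data shown here, replacing 4-(tert-butyl)phenyl with octyl in this assay gives a number 1.4 percentage points higher from compound 1 to compound 3 (within the scatter) and is the first measured step at this aromatic carbon, next to the ring nitrogen. It shows that compound 3 cannot be told apart from compound 1 here, so a six-membered aromatic ring at this position is not needed for a high reading at this single concentration, although any difference in potency could stay hidden with both readings so high. Nothing measured here explains this match.

From the compounds shown here alone, it remains open whether a much shorter chain, such as methyl or butyl, would give a similar reading at this carbon on the core of compound 1. Going by these compounds, it is also open whether a chain ending in an amine or a carboxylic acid would do so.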